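A few compounds are considered here, and "the series" means these few. Any claim that something is new, unique, unknown or untested is made for them only; others in the source may bear on it.

Measured compounds:
- compound 1 `COc1ccc(/C=N/n2c(SCc3ccc(F)cc3)nnc2-c2cc(OC)c(OC)c(OC)c2)c(OC)c1`. In a functional assay on MKN-45 cells (Homo sapiens) for cytotoxicity, read by MTT assay, with a stated time of 48 h (a lower number here means a stronger inhibitor, a higher number a weaker inhibitor), compound 1 gives > 200000 nM, which is a limit of the assay and not a number.
- compound 2 `COc1ccc(/C=N/n2c(SCc3ccccc3Cl)nnc2-c2cc(OC)c(OC)c(OC)c2)c(OC)c1`. In this assay compound 2 gives > 200000 nM, again a limit of the assay.

Compound 2 therefore stands at the limit of > 200000 nM in this assay, at which 2 of the 2 values shown sit, with no number of its own. Within the data shown here, the only measured step, a step that the two limits leave unreadable from compound 1 to compound 2, cannot be read because both of its ends sit at the limit of > 200000 nM in this assay, at which 2 of the 2 values shown sit.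

Compound 3 `COc1ccc(/C=N/n2c(SCc3ccccc3)nnc2-c2cc(OC)c(OC)c(OC)c2)c(OC)c1` differs from compound 2 by hydrogen in place of chloro on an aromatic carbon. No measured step bears on this change with a readable size, and nothing in the shown values separates compound 1 from compound 2. The expectation is that the step that the limit leaves unreadable from compound 2 to compound 3 is none beyond the scatter, with compound 3 most likely again reported only as a limit. Compound 3 is thus estimated at 300000 nM, with a range from 100000 nM to 1000000 nM in this assay.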

Compound 3, half-maximal inhibitory concentration: 49000 nM
Estimate against measurement, compound 3: 6.1-fold (0.79 log units) above; measured number below the stated range.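

In this assay, hydrogen in place of chloro on the aromatic carbon gives an at least 4.0-fold lower number from compound 2 to compound 3 (0.61 log units; beyond the scatter), and hydrogen in place of fluoro gives an at least 4.0-fold lower number from compound 1 to compound 3 (0.61 log units; beyond the scatter). The substitution on this benzyl ring therefore registers in this assay, which the earlier pair could not show, and among these three compounds only the one without a halogen has a number of its own. Both steps are lower bounds only, because each halogen-bearing compound sits at a limit of the assay and not at a number: the limit of > 200000 nM in this assay, at which 2 of the 3 values shown sit.

Going by these compounds, the step between the two halogen-bearing compounds cannot be read, so any difference between chloro and fluoro stays unknown. Also open, on these data alone, is how a methoxy group or an amine on this ring, or a longer chain to the sulfur, would compare with the plain benzylsulfanyl group.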